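One amine tail for another on a shared core

The source may hold more compounds than are shown below. What is called first, only, known or untested is meant among the compounds shown, and "the series" means these compounds.

Compound 1 `CC(=O)Oc1ccc(C(=O)Nc2cc3ccc(OCCC4CCCCN4)c(C)c3oc2=O)cc1CC=C(C)C`: 640 nM
Compound 2 `CC(C)=CCc1cc(C(=O)Nc2cc3ccc(OCCCNCC(C)C)c(C)c3oc2=O)ccc1O`: 1030 nM

In a functional assay on SK-BR-3 cells (Homo sapiens) for antiproliferative activity (a lower number here means a stronger inhibitor, a higher number a weaker inhibitor), compound 2 carries the larger of the two numbers, yet its gap to compound 1 lies within the scatter, so neither compound can be called the stronger inhibitor on this evidence. Compound 3 `CC(C)=CCc1cc(C(=O)Nc2cc3ccc(OCCCN(C)Cc4ccccc4)c(C)c3oc2=O)ccc1O` differs from compound 2 in a single place: benzyl(methyl)amino in place of isobutylamino on a saturated chain carbon, three bonds along the chain from an oxygen on an aromatic ring. Within the data shown here, no pair of measured compounds shows this change, so nothing here tells its size. The step of a 1.3-fold lower number from compound 2 to compound 3 (0.11 log units; within the scatter) is expected to stay within the scatter, in either direction. Compound 3 is estimated at 800 nM, with a range from 300 nM to 2500 nM.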

Compound 3, half-maximal inhibitory concentration: 10700 nM
Compound 3: the middle estimate sits 13-fold (1.13 log units) below what was measured; measured number above the stated range.
By their numbers in this assay, from the lowest: compounds 1 and 2 (each within the scatter of the next); then compound 3.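

In this assay, the amine at the end of the chain clearly matters: benzyl(methyl)amino in place of isobutylamino gives a 10-fold higher number from compound 2 to compound 3 (1.02 log units; beyond the scatter). Compound 1 and compound 2 differ in more than one place, so they could not show this. The change adds an aromatic ring and removes the hydrogen-bond donor together, and nothing measured here explains the weaker result. Which of these two differences matters remains open. A benzylamino group, which keeps the nitrogen hydrogen, or a dimethylamino group, which has no ring, would help separate them.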